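The source may report more compounds than this note shows. Statements on the series, on what has been measured and on what is new or still open speak of the compounds shown alone.

Three compounds that share one core and differ only in the group on a sulfonyl sulfur have been measured in an ADME assay on microsomes from liver (Homo sapiens) for pharmacokinetics, read by LC-MS, with a stated time of 60 min, tested at 1 uM; a higher number here means faster removal of the compound, a lower number slower removal. Compound 1 `C[C@@H]1CN(S(=O)(=O)c2ccc(NC(=O)NCc3cccnc3)cc2)C[C@H](C)O1` gives 17 mL/min/kg, compound 2 `O=C(NCc1cccnc1)Nc1ccc(S(=O)(=O)N2C3CCC2COC3)cc1` gives 8 mL/min/kg, and compound 3 `O=C(NCc1cccnc1)Nc1ccc(S(=O)(=O)N2CCCNCC2)cc1` gives 6 mL/min/kg. Compound 3 sits at the low end of this small set, though it shares that position with compound 2. The first comparison shows a 2.8-fold lower number from compound 1 to compound 3 (0.45 log units; beyond the scatter), whereas the second shows a 1.3-fold lower number from compound 2 to compound 3 (0.12 log units; within the scatter), so those two cannot be told apart.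

Compound 4 `N[C@H]1CC[C@H](NS(=O)(=O)c2ccc(NC(=O)NCc3cccnc3)cc2)CC1` has not yet been measured. The change that leads to it is (4-aminocyclohexyl)amino in place of 1,4-diazepan-1-yl on a sulfonyl sulfur, again on the sulfonyl sulfur. The other measured change at this place, a 2.1-fold lower number from compound 1 to compound 2 (0.33 log units; beyond the scatter), is also modest. Going by the values given here, no measured compound carries the (4-aminocyclohexyl)amino group, so these steps are only a rough guide. Compound 3, at 6 mL/min/kg, is the natural starting point, and the largest step seen at this place is a 2.8-fold lower number from compound 1 to compound 3 (0.45 log units; beyond the scatter). On that evidence, no clear rise or fall is expected in this assay. The expected change is a 1.2-fold higher number from compound 3 to compound 4 (0.07 log units; within the scatter), an estimate that carries real uncertainty. For compound 4 the estimated clearance is 7 mL/min/kg, with an expected range of 3 mL/min/kg to 16 mL/min/kg.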

Compound 4, clearance: 5 mL/min/kg
Estimate against measurement, compound 4: 1.4-fold (0.15 log units) above, within the range that was stated.
By their numbers in this assay, from the lowest: compounds 4, 3 and 2 (each within the scatter of the next); then compound 1.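

In this assay, the (4-aminocyclohexyl)amino group on the sulfonyl sulfur cannot be told apart from 1,4-diazepan-1-yl (a 1.2-fold lower number from compound 3 to compound 4 (0.08 log units; within the scatter)) or from the bridged group of compound 2 (a 1.6-fold lower number from compound 2 to compound 4 (0.20 log units; within the scatter)). Going by these compounds alone, this adds something new: the earlier compounds all carried a non-aromatic ring with hetero atoms here, whereas this six-membered ring of carbon only, bearing an amino group and 2 defined stereocentres, still falls in the same group of numbers. Compound 1 remains the one that stands apart, and the 2,6-dimethylmorpholin-4-yl group shows the clearest step at this position (a 3.4-fold lower number from compound 1 to compound 4 (0.53 log units; beyond the scatter)). Nothing shown here gives a measured reason why these different groups behave so alike.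

Going by these compounds, what remains open is whether the other stereochemical form of the (4-aminocyclohexyl)amino group would give a similar number. On these data alone, it is also open whether clearance stays in this range with a carboxylic acid in place of the amino group on the carbon ring, or with an open chain such as 2-aminoethylamino on the sulfonyl sulfur.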